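A few compounds are considered here, and "the series" means these few. Any claim that something is new, unique, unknown or untested is made for them only; others in the source may bear on it.

Four compounds share a core built around two linked piperazine rings. Compound 1 `COc1cccc(N2CCN(CC(=O)N3CCN(c4nnc(-c5ccccc5)c(-c5ccccc5)n4)CC3)CC2)c1` and compound 2 `O=C(CN1CCN(c2cccc(Cl)c2)CC1)N1CCN(c2nnc(-c3ccccc3)c(-c3ccccc3)n2)CC1` differ only by the change (chloro in place of methoxy on an aromatic carbon). Compound 3 `COc1ccccc1N1CCN(CC(=O)N2CCN(c3nnc(-c4ccc(Cl)cc4)c(-c4ccc(Cl)cc4)n3)CC2)CC1` carries a different core, and the difference between the cores of compound 1 and compound 3 is not broken down here. Going by the values given here, compound 4 `O=C(CN1CCN(c2ccccc2Cl)CC1)N1CCN(c2nnc(-c3ccc(Cl)cc3)c(-c3ccc(Cl)cc3)n2)CC1` is not yet measured and differs from compound 3 by the change (chloro in place of methoxy on an aromatic carbon), the same kind of change as the one from compound 1 to compound 2, though made ortho to a large group rather than meta to it.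

In a functional assay on MCF7 cells (Homo sapiens) for cytotoxicity, read by MTT assay, with a stated time of 24 h (on this read-out lower numbers stand for stronger inhibition and higher numbers for weaker inhibition), compound 1 gives only a limit, > 910000 nM. Compound 2 gives 56300 nM in this assay, so the step of an at least 16-fold lower number from compound 1 to compound 2 (1.20 log units; beyond the scatter) is at least that large, with the lower end set by the limit of > 910000 nM in this assay, at which 1 of the 3 values shown sits. Compound 3 gives 330000 nM in this assay.

For compound 4 a step of a 4.1-fold lower number from compound 3 to compound 4 (0.62 log units; beyond the scatter) is expected, smaller than the earlier one, since that earlier step rests on a limit and the new change sits ortho rather than meta. Compound 4 is therefore estimated at 80000 nM, between 20000 nM and 330000 nM.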

Compound 4, half-maximal inhibitory concentration: 396000 nM
Estimate against measurement, compound 4: 5.0-fold (0.69 log units) below; measured number outside the range, above it.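

In this assay, putting chloro in place of methoxy gives a 1.2-fold higher number from compound 3 to compound 4 (0.08 log units; within the scatter), so on this core the change has no effect that can be told from scatter, and the result does not match the earlier pair: the same change on two cores in this assay, an at least 16-fold lower number (1.20 log units; beyond the scatter) from compound 1 to compound 2 and a 1.2-fold higher number (0.08 log units; within the scatter) from compound 3 to compound 4, at least 19-fold (1.28 log units) apart, beyond the scatter of two such steps. As far as these compounds go, the earlier step rests on compound 1, whose reading is a limit and not a number, so its true size is unknown: the limit of > 910000 nM in this assay, at which 1 of the 4 values shown sits. The new change sits ortho to a large group and the earlier one does not, and the cores differ as well, so these compounds show that the step did not carry over but not whether the core or the position accounts for the gap.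

Still open, from the compounds shown here alone, is how the change would read if it were made at the same ring position on both cores. Also open, going by these compounds, is how a methyl, a fluoro or a hydroxyl on that aromatic ring would compare with methoxy and chloro on either core.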